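The compounds below may be only part of what the source reports. "The series", "measured", "known", "first", "only" and "open" are said of these compounds alone.

Measured in a physicochemical assay for solubility, measured as kinetic solubility; on this read-out higher numbers stand for higher solubility and lower numbers for lower solubility:
- compound 1 `Cc1cc(C)c(CN2CCc3c(Cl)cc(-c4c(C)noc4C)c(Cl)c3C2=O)c(=O)[nH]1`: 93000 nM
- compound 2 `COC(c1cc(Cl)c2c(c1Cl)C(=O)N(Cc1c(C)cc(C)[nH]c1=O)CC2)C1CCOCC1`: 57500 nM; 57200 nM (2 entries)

Within the data shown here, compound 1 gives the only single number here, while compound 2 has repeat entries instead: the several entries of compound 2 in this assay, 57500 nM; 57200 nM (2 entries). The values of these two compounds lie within the usual scatter of each other, so compound 1 cannot be ranked against compound 2.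

Compound 3 `COc1cc(C)[nH]c(=O)c1CN1CCc2c(Cl)cc(-c3c(C)noc3C)c(Cl)c2C1=O` keeps the core of compound 1 but has methoxy in place of methyl on an aromatic carbon, opposite the ring nitrogen: methoxy in place of methyl on an aromatic carbon. Among the measured compounds shown here, no measured pair shows this change, so the data give no direct guide to its size. In this assay, no step beyond the scatter is expected. The estimated step, a 1.2-fold lower number from compound 1 to compound 3 (0.07 log units; within the scatter), is expected to stay within that scatter. For compound 3 the expected value is 80000 nM, with an estimated range of 40000 nM to 150000 nM.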

Compound 3, solubility: 384000 nM
For compound 3 the middle estimate is 4.8-fold (0.68 log units) below the measured one; the measured number lies above the stated range.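

In this assay, methoxy in place of methyl on an aromatic carbon, opposite the ring nitrogen, gives a 4.1-fold higher number from compound 1 to compound 3 (0.62 log units; beyond the scatter). Among these compounds, this is the first step measured at this position, and it shows that exchanging one group here for another can move the read-out beyond the scatter, even though the rest of compound 3 matches compound 1. Repeat entries of one compound can agree closely in this assay, so a step of this size is hard to dismiss as noise, as this example shows: the several entries of compound 2 in this assay, 57500 nM; 57200 nM (2 entries).

This one pair does not say why the number rose, or whether ethoxy, an amine or a fluorine atom at the same position would shift it in the same way. It also leaves open whether methoxy would give a similar step on compound 2.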